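Nitro for Fluoro on Two Related Bicyclic Piperazine Cores

This account rests on a few compounds, and the source may have more. Where it says the series, first, only, none or still open, it means among the compounds named here.

The measured compounds are:

Compound 1, `O=C1C2CCCCN2C(=O)N1CN1CCN(c2ccc(F)cc2)CC1`, which in an assay on isolated protein for binding affinity to Adrenergic receptor alpha-1 (Rattus norvegicus), read by radioligand binding (a higher number here means a weaker inhibitor, a lower number a stronger inhibitor), gives 869 nM.
Compound 2, `O=C1C2CCCCN2C(=O)N1CN1CCN(c2ccc([N+](=O)[O-])cc2)CC1`, which in this assay gives > 10000 nM; this is a limit of the assay rather than a number, sitting at the limit of > 10000 nM in this assay, at which 1 of the 3 values shown sits.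
Compound 3, `O=C1C2CCCN2C(=O)N1CCN1CCN(c2ccc(F)cc2)CC1`, which in this assay gives > 1000 nM; this too is a limit, sitting at the limit of > 1000 nM in this assay, at which 1 of the 3 values shown sits.

Compound 2 arises from compound 1 by nitro in place of fluoro on an aromatic carbon, and this change gave an at least 11-fold higher number from compound 1 to compound 2 (1.06 log units; beyond the scatter). Compound 3 shares its atoms with compound 1 but joined differently; the difference between the two cores is not broken down here.

The unmeasured compound 4, `O=C1C2CCCN2C(=O)N1CCN1CCN(c2ccc([N+](=O)[O-])cc2)CC1`, arises from compound 3 by nitro in place of fluoro on an aromatic carbon, the same kind of change as that from compound 1 to compound 2, made at a place described in the same words. Compound 3 already gives only a limit, so a step that the limit leaves unreadable from compound 3 to compound 4 is expected, resting on the fact that the same kind of change gave an at least 11-fold higher number from compound 1 to compound 2 (1.06 log units; beyond the scatter). Compound 4 is therefore expected to give 20000 nM, estimated between 5000 nM and 80000 nM, most likely again as a limit.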

Compound 4, inhibition constant: > 10000 nM
Compound 4: no number, only a limit (the forecaster's own chance of this, stated with the estimate: 85%); the middle value is on the limit's open side.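

For the compounds shown here, compound 3 and compound 4 both give only limits of the assay in this assay, so no step between them can be read. The compounds shown leave open how far nitro in place of fluoro shifts the affinity on the core of compound 3, and whether that shift matches the one seen on the core of compound 1.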